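A Smaller Acyl Group on the Amide

The source may report more compounds than this note shows. Statements on the series, on what has been measured and on what is new or still open speak of the compounds shown alone.

In a functional assay on U-87MG ATCC cells (Homo sapiens) for inhibition (a higher number here means a weaker inhibitor, a lower number a stronger inhibitor), compound 1 (`COc1cc(/C=C/C(=O)c2cccc(NC(=O)c3ccc(Cl)cc3Cl)c2)ccc1O`) gives > 50 ug/mL, which is a limit of the assay and not a number. Within the data shown here, compound 2 (`COc1cc(/C=C/C(=O)c2cccc(NC(=O)c3ccccc3)c2)ccc1O`) gives 8.82 ug/mL, the only true number so far, and so it has no measured value to be ranked against. Among the measured compounds shown here, the one measured step, an at least 5.6-fold lower number from compound 1 to compound 2 (0.75 log units; beyond the scatter), replaced the larger group with the smaller one and brought a clear gain in this assay.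

Compound 3 (`COc1cc(/C=C/C(=O)c2cccc(NC(C)=O)c2)ccc1O`) takes the reduction further. The change is methyl in place of phenyl on a carbonyl carbon, or benzamido to acetamido. The earlier step bears on this only loosely: an at least 5.6-fold lower number from compound 1 to compound 2 (0.75 log units; beyond the scatter) kept an aromatic ring on the carbonyl carbon, while compound 3 has none. For the measured compounds named here, no measured step shows what losing that ring does. A smaller group gave the lower number once, but one step cannot set a direction here, so only a slight weakening is expected. The estimated change, a 1.4-fold higher number from compound 2 to compound 3 (0.13 log units; within the scatter), is expected to stay within the scatter. For compound 3 the expected value is 12 ug/mL, with an estimated range from 4 ug/mL to 35 ug/mL.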

Compound 3, half-maximal inhibitory concentration: > 50 ug/mL
Compound 3: only a limit was reported; the forecaster's own chance of this, stated with the estimate: 10%; middle value at least 4.1-fold (0.61 log units) away from the limit.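

At this position, on a carbonyl carbon whose other neighbour is the amide-type nitrogen, putting methyl in place of phenyl gives an at least 5.6-fold higher number from compound 2 to compound 3 (0.75 log units; beyond the scatter) in this assay, and this runs against the earlier step, an at least 5.6-fold lower number from compound 1 to compound 2 (0.75 log units; beyond the scatter). A smaller group on the carbonyl carbon therefore does not lower the number steadily: the 2,4-dichlorophenyl of compound 1 and the methyl of compound 3 both go with a limit, and only the phenyl of compound 2 goes with a true number, so among these three compounds the plain phenyl is the one group with a measurable value. The step between compound 1 and compound 3 cannot be read, because both stand at the same limit: the limit of > 50 ug/mL in this assay, at which 2 of the 3 values shown sit.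

What the compounds leave open is whether the gain depends on an aromatic ring on the carbonyl carbon or could also be reached with a saturated ring such as cyclohexyl or a longer chain such as propyl. They also leave open whether a phenyl carrying a single chlorine, or a methoxy group, would stay near compound 2 or fall back to the limit.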